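Swapping a sulfonamide for an amide on a shared core

The source may report more compounds than this note shows. Statements on the series, on what has been measured and on what is new or still open speak of the compounds shown alone.

The series shares one core, seen in compound 1 `COc1ccc(-c2cc(-c3ccc(S(=O)(=O)N(C)C)cc3)cnc2N)cn1`, compound 2 `COc1ccc(-c2cc(-c3ccc(S(C)(=O)=O)cc3C(F)(F)F)cnc2N)cn1`, and compound 3 `COc1ccc(-c2cnc(N)c(-c3ccc(OC)nc3)c2)cn1`. In a physicochemical assay for lipophilicity, at pH 7.4 (on this read-out lower numbers stand for lower lipophilicity and higher numbers for higher lipophilicity), compound 1 gives 2.8, compound 3 gives 2.8, and compound 2 gives 2.7. Compound 1 and compound 3 are level at the digits shown, the pair standing highest of the three, and compound 2 sits only a little lower, a gap that falls within the usual scatter of this assay, so no order can be read among them.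

Compound 4 `CNC(=O)c1ccc(-c2cnc(N)c(-c3ccc(OC)nc3)c2)cc1` has not yet been measured in this assay. It differs from compound 1 in one place, (methylcarbamoyl in place of dimethylsulfamoyl on an aromatic carbon), on an aromatic carbon of a six-membered aromatic ring of carbon only, para to a large group. Among the measured compounds shown here, no measured pair shows this exact exchange, so the step must be judged from the groups themselves; the entering methylcarbamoyl brings a hydrogen-bond donor where dimethylsulfamoyl had none, and carries fewer heavy atoms. The step from compound 1 to compound 4 is expected to be a modest fall, a number 0.40 log units lower from compound 1 to compound 4 (beyond the scatter), close to the edge of the scatter. Compound 4 is therefore estimated at 2.4, within a range from 2 to 2.8.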

Compound 4, distribution coefficient: 1.8
Beside the measured number, compound 4's estimate is 0.60 log units above it; the measured number lies below the stated range.
By their numbers in this assay, from the lowest: compound 4; then compounds 2, 1 and 3 (each within the scatter of the next).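

In this assay, methylcarbamoyl in place of dimethylsulfamoyl on this aromatic carbon gives a number 1.00 log units lower from compound 1 to compound 4 (beyond the scatter). Compounds 1, 2 and 3 had stood within the scatter of one another, so this is the first step shown that clears it, and it marks this position, para to a large group, as one where the read-out responds to the group it carries. The entering group brings a hydrogen-bond donor and has fewer heavy atoms, but no measurement shown accounts for the size of the step.

Going by these compounds, whether the step follows the donor, the heavy-atom count or the change from sulfonyl to carbonyl stays open. A dimethylcarbamoyl or a methylsulfamoyl group on the same carbon would pull these differences apart, and nothing shown tells how far the step carries to other groups here.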